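Replacing vinyl with prop-1-yn-1-yl: an expected recovery

A few compounds are considered here, and "the series" means these few. Any claim that something is new, unique, unknown or untested is made for them only; others in the source may bear on it.

Of the compounds shown here, three have been measured in a functional assay on NCI-H522 cells (Homo sapiens) for cytotoxicity, with a stated time of 3 days; a lower number here means a stronger inhibitor, a higher number a weaker inhibitor. Compound 1 `C#Cc1nc2ccccc2n1C` gives 8140 nM. Compound 2 `C#Cc1nc(C(=O)OCC)cs1`, which carries an ethynyl on the five-membered aromatic ring with 1 nitrogen and 1 sulfur, gives 2670 nM. Compound 3 `C=Cc1nc(C(=O)OCC)cs1` sits at the limit of > 40000 nM in this assay, at which 1 of the 3 values shown sits. Its reading of > 40000 nM is therefore a limit of the assay and not a number.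

Among the compounds with values here, the one measured step that bears on the next move is an at least 14-fold higher number from compound 2 to compound 3 (1.17 log units; beyond the scatter). Going by these compounds, exchanging the ethynyl for a vinyl on that aromatic carbon thus weakened the inhibitor by a large margin, and the true size of the loss is unknown since compound 3 only reached the limit.

Compound 4 `CC#Cc1nc(C(=O)OCC)cs1` differs from compound 3 as follows: prop-1-yn-1-yl in place of vinyl on an aromatic carbon. This reinstates a triple bond outside aromatic rings at the same aromatic carbon, now carrying a methyl cap, so the change reverses the direction of the step from compound 2 to compound 3. Compound 4 is therefore expected to show a lower number than compound 3, by an at least 5.0-fold lower number from compound 3 to compound 4 (0.69 log units; beyond the scatter), though how closely it returns toward compound 2 cannot be told from an ethynyl alone. The estimate for compound 4 is 8000 nM, with a range from 2000 nM to 40000 nM.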

Compound 4, half-maximal inhibitory concentration: > 40000 nM
Compound 4 was reported as a limit; the forecaster's own chance of this, stated with the estimate: 25%; at least 5.0-fold (0.69 log units) between middle value and limit.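

In this assay compound 4 gives a limit of the assay and not a number: the limit of > 40000 nM in this assay, at which 2 of the 4 values shown sit. Methyl in place of hydrogen on the triple-bonded carbon produces an at least 14-fold higher number from compound 2 to compound 4 (1.17 log units; beyond the scatter), so at this aromatic carbon, next to the ring nitrogen and next to the ring sulfur, a triple bond outside aromatic rings does not by itself keep the activity seen with the ethynyl. Of the four compounds, only compound 1 and compound 2, the two that carry an ethynyl, give a number rather than a limit, while the step from compound 3 to compound 4 cannot be read, and the vinyl and prop-1-yn-1-yl groups cannot be put in any order.

The compounds shown leave open whether a chlorine atom or a hydroxymethyl group on the triple-bonded carbon would fare any differently from methyl. They also leave open whether the ethynyl would keep its reading on this core with a carboxylic acid or an amide in place of the ethyl ester.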